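The compounds below may be only part of what the source reports. "The series", "measured", "known", "first", "only" and "open" are said of these compounds alone.

Measured so far:
compound 1 `CC(C)NC(=O)c1ccc(C#Cc2ccccc2)nc1` – 7100 nM
compound 2 `Cc1ccccc1C#Cc1ccc2c(n1)CCN(C)C2=O` – > 32000 nM

In an assay on HEK293 cells for displacement of a labelled ligand from metabotropic glutamate receptor 5 (Homo sapiens), with a stated time of 2 h (on this read-out lower numbers stand for stronger inhibition and higher numbers for weaker inhibition), compound 1 gives 7100 nM. For compound 2 this assay reports only a limit, > 32000 nM, and no number. Compound 2 therefore stands at the limit of > 32000 nM in this assay, at which 1 of the 2 values shown sits, the weaker end of what has been measured so far. The next compound, compound 3 `CN1CCc2nc(C#Cc3ccc(Cl)cc3)ccc2C1=O`, keeps the core of compound 2 and differs in one place: 4-chlorophenyl in place of 2-methylphenyl on a triple-bonded carbon. Within the data shown here, no measured pair covers this change, so its size is open. Because compound 2 is known only as the limit > 32000 nM, the step to compound 3 can be stated only loosely; a modest move toward the stronger side of the limit is expected rather than none, though a further limit reading remains plausible. Compound 3 is expected to give 15000 nM, with a range of 3000 nM to 60000 nM. The step of an at least 2.1-fold lower number from compound 2 to compound 3 (0.32 log units; beyond the scatter) is expected to run toward stronger binding, beyond the usual scatter.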

Compound 3, inhibition constant: 6150 nM
The estimate for compound 3 lay 2.4-fold (0.39 log units) above the measured number, within the range that was stated.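

In this assay, 4-chlorophenyl in place of 2-methylphenyl on a triple-bonded carbon gives an at least 5.2-fold lower number from compound 2 to compound 3 (0.71 log units; beyond the scatter). This position on the shared core therefore responds to the group it carries, even though the leaving and entering groups have the same count of heavy atoms and neither has hydrogen-bond donors or acceptors. The full size of the step remains unknown because compound 2 is represented by a limit and not a number: the limit of > 32000 nM in this assay, at which 1 of the 3 values shown sits.

This single pair cannot show whether the step follows from the entry of the chlorine, the loss of the methyl or the different place of substitution on the ring. From the compounds shown here alone, how a methoxy group or a nitrile in place of the chlorine would read also remains open.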